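Two quinazoline anilines beyond the assay limit; a third awaited

The source may report more compounds than this note shows. Statements on the series, on what has been measured and on what is new or still open speak of the compounds shown alone.

Compound 1 `FC(F)(F)c1ccc(CSc2nc(Nc3ccccc3Cl)c3ccccc3n2)cc1`: > 50000 nM
Compound 2 `O=[N+]([O-])c1cccc(Nc2nc(SCc3ccc(C(F)(F)F)cc3)nc3ccccc23)c1`: > 50000 nM

In a functional assay on MGC-803 cells (Homo sapiens) for cytotoxicity, read by MTT assay, with a stated time of 72 h (on this read-out lower numbers stand for stronger inhibition and higher numbers for weaker inhibition), compound 1 gives > 50000 nM, which is a limit of the assay and not a number. In this assay compound 2 likewise gives > 50000 nM, again a limit. The step that the two limits leave unreadable from compound 1 to compound 2 is therefore unreadable; both values sit at the limit of > 50000 nM in this assay, at which 2 of the 2 values shown sit. Compound 3 `Cc1ccc(Nc2nc(SCc3ccc(C(F)(F)F)cc3)nc3ccccc23)cc1` differs from compound 2 by 4-methylphenyl in place of 3-nitrophenyl on a nitrogen on an aromatic ring. For the measured compounds named here, no measured step reads across this change, so no direction can be read from the data. Compound 3 is expected to remain near the limit, an estimated step of a number no higher from compound 2 to compound 3 (the limit leaves the size open), giving an estimate of 50000 nM with a range from 15000 nM to 200000 nM.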

Compound 3, half-maximal inhibitory concentration: 36100 nM
For compound 3 the middle estimate is 1.4-fold (0.14 log units) above the measured one; the measured number falls inside the stated range.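

As far as these compounds go, with 4-methylphenyl on the nitrogen, compound 3 gives the first result in this assay that is a number and not a limit: the limit of > 50000 nM in this assay, at which 2 of the 3 values shown sit. The change reads as an at least 1.3-fold lower number from compound 2 to compound 3 (0.14 log units; that floor lies within the scatter) and as an at least 1.3-fold lower number from compound 1 to compound 3 (0.14 log units; that floor lies within the scatter), so the true size of each step remains unknown. The step between compound 1 and compound 2 cannot be read, which leaves their 2-chlorophenyl and 3-nitrophenyl groups unordered. From the compounds shown here alone, whether an amine or a carboxylic acid on this phenyl ring, or a longer chain in place of the methyl, would give a lower number stays open.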